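The source may hold more compounds than are shown below. What is called first, only, known or untested is meant among the compounds shown, and "the series" means these compounds.

Measured so far in a functional assay on the whole organism (plasma, strain Wistar) with Rattus norvegicus as the target, with a stated time of 15 days, at a dose of 10 mg/kg by the oral route; on this read-out higher numbers stand for a stronger effect at the one dose given and lower numbers for a weaker effect:
- compound 1, `O=C1NC(=O)/C(=C/c2ccc(OCCSc3nnc(-c4ccccc4)[nH]3)cc2)S1`: 10.6%
- compound 2, `O=C1NC(=O)/C(=C/c2ccc(OCCSc3nnc(-c4ccc(Cl)cc4)[nH]3)cc2)S1`: 19.6%

Of these two numbers compound 2 holds the higher one, yet the step of a number 9 percentage points higher from compound 1 to compound 2 (within the scatter) lies within the scatter, so the two compounds cannot be told apart on this read-out.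

Compound 3, `O=C1NC(=O)/C(=C/c2ccc(OCCSc3nnc(-c4ccc(Br)cc4)[nH]3)cc2)S1`, differs from compound 2 by bromo in place of chloro on an aromatic carbon. Within the data shown here, no measured step sets bromo against chloro. Among the measured compounds shown here, the one step available is a number 9 percentage points higher from compound 1 to compound 2 (within the scatter), which concerns chloro against hydrogen at the same place and was small. With a halogen kept at that place and only its identity changed, no step beyond the scatter is expected in this assay, in either direction; the expected step is a number 2.4 percentage points higher from compound 2 to compound 3 (within the scatter). The estimate for compound 3 in this assay is therefore 22%, with a range from 10% to 36%.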

Compound 3, a percentage reported as activity, at one dose (the size of the read-out at that dose, not a potency): 20.4%
For compound 3 the middle estimate is 1.6 percentage points above the measured one, within the range that was stated.
By their numbers in this assay, from the lowest: compounds 1, 2 and 3 (each within the scatter of the next).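

In this assay, bromo in place of chloro on an aromatic carbon para to a large group gives a number 0.8 percentage points higher from compound 2 to compound 3 (within the scatter), so the identity of the halogen at this place makes no difference that can be read for these two compounds. Bromo in place of hydrogen at the same place gives a number 9.8 percentage points higher from compound 1 to compound 3 (within the scatter), so, like chloro, bromo cannot be told apart from hydrogen here on this read-out. Nothing available bears on why these compounds read as they do.

Whether this place can move the read-out beyond the scatter at all remains open, since only hydrogen and two halogens are shown there. An amine or a carboxylic acid at this place could answer that, and the effect of a longer chain in the linker of the shared core is also unknown.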